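A few compounds are considered here, and "the series" means these few. Any claim that something is new, unique, unknown or untested is made for them only; others in the source may bear on it.

Working notes on the series.

Three compounds of the shared core have numbers in an assay on membranes from liver for displacement of a labelled ligand from Glucagon receptor (Mus musculus), read by scintillation counting, with a stated time of 60 min; on this read-out lower numbers stand for stronger inhibition and higher numbers for weaker inhibition. Compound 1 `C[C@H](c1ccc(C(=O)NCCC(=O)O)cc1)N1C(=O)C(c2ccc(F)cc2)=N[C@]12CC[C@@H](C(C)(C)C)CC2` gives 2500 nM in this assay. Compound 2 `CCC[C@H](c1ccc(C(=O)NCc2nn[nH]n2)cc1)N1C(=O)C(c2cc(Cl)cc(Cl)c2)=N[C@]12CC[C@@H](C(C)(C)C)CC2` gives 500 nM in this assay, the second highest of the three numbers; compound 3 `CC(C)(C)CC[C@H](c1ccc(C(=O)NCc2nn[nH]n2)cc1)N1C(=O)C(c2cccc(C(F)(F)F)c2)=N[C@]12CC[C@@H](C(C)(C)C)CC2` gives 140 nM in this assay, the lowest, and both gaps from compound 2 lie beyond the usual scatter. Among the compounds with values here, no pair of these three differs in a single place, so no single change can be read off from the measured numbers alone; compound 3 carries a longer branched chain together with a different aryl group and a different acidic end than compound 1.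

Compound 4 `CC(C)CC[C@H](c1ccc(C(=O)NCc2nn[nH]n2)cc1)N1C(=O)C(c2cc(Cl)cc(Cl)c2)=N[C@]12CC[C@@H](C(C)(C)C)CC2` has not been measured in this assay. It differs from compound 2 in one place: isopropyl in place of methyl on a saturated chain carbon, three bonds along the chain from an amide-type nitrogen in a ring and an aromatic carbon. The only hint on chain length comes from compound 3, whose value of 140 nM is the lowest, yet it differs in more than one place. A modest step downward from compound 2 to compound 4 is expected, a 2.0-fold lower number from compound 2 to compound 4 (0.30 log units; within the scatter), with wide uncertainty. Compound 4 is estimated at 250 nM in this assay, within 90 nM to 700 nM.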

Compound 4, half-maximal inhibitory concentration: 280 nM
The estimate for compound 4 lay 1.1-fold (0.05 log units) below the measured number; the range from low to high includes it.
By their numbers in this assay, from the lowest: compounds 3, 4 and 2 (each within the scatter of the next, the first and the last beyond it); then compound 1.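

At this position, on a saturated chain carbon three bonds along the chain from an amide-type nitrogen in a ring and an aromatic carbon, isopropyl in place of methyl gives a 1.8-fold lower number from compound 2 to compound 4 (0.25 log units; within the scatter) in this assay. Within the data shown here, this is the first single-place comparison, and it shows that propyl and isopentyl at this point are not separated beyond the scatter, so branching and extending the chain this far leaves the number unresolved from that of compound 2. Nothing on hand explains this result.

From the compounds shown here alone, whether a longer straight chain such as hexyl, a cyclohexyl group or a terminal amine at this position would separate from isopentyl remains open. The chain in compound 3 cannot be assessed on its own, since that compound differs from the others in more than one place.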